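Swapping methyl for bromo on a five-ring core: a second look

The source may report more compounds than this note shows. Statements on the series, on what has been measured and on what is new or still open speak of the compounds shown alone.

Of the compounds shown here, three from this set have been tested for their effect on the growth of lung cancer cells, and a fourth awaits its number. Compound 1 `COC(=O)[C@@]1(C)CC[C@@H]2C3=C1CC[C@@H](C)[C@]3(C)C[C@@H]1c3cc(C)ccc3N[C@H]21` carries a methyl group on an aromatic carbon, and in a functional assay on A549 cells (Homo sapiens) for inhibition, read by sulforhodamine B assay, with a stated time of 48 h (on this read-out higher numbers stand for weaker inhibition of growth and lower numbers for stronger inhibition of growth), compound 1 gives 27000 nM. Compound 2 `COC(=O)[C@@]1(C)CC[C@@H]2C3=C1CC[C@@H](C)[C@]3(C)C[C@@H]1c3cc(Br)ccc3N[C@H]21` differs from it in one place, (bromo in place of methyl on an aromatic carbon), and in this assay compound 2 gives 40000 nM. The change produced a 1.5-fold higher number from compound 1 to compound 2 (0.17 log units; within the scatter), a step too small to be told apart from repeat measurement noise.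

Compound 3 `COC(=O)[C@@]1(C)CC[C@@H]2C3=C1CC[C@@H](C)[C@]3(C)Cc1c2[nH]c2ccc(C)cc12` is built on a different core; the difference between the two cores is not broken down here. In this assay compound 3 gives 16000 nM. Against compound 1 this is a gap within the scatter, while against compound 2 the gap is beyond it.

Compound 4 `COC(=O)[C@@]1(C)CC[C@@H]2C3=C1CC[C@@H](C)[C@]3(C)Cc1c2[nH]c2ccc(Br)cc12` is the counterpart of compound 3 in the same way that compound 2 is the counterpart of compound 1: the change is bromo in place of methyl on an aromatic carbon, and the surroundings of the altered carbon are described in identical words for both pairs, so this is the same change made on a second core. The expected step is a 1.5-fold higher number from compound 3 to compound 4 (0.18 log units; within the scatter), an expectation that rests on the same change having produced a 1.5-fold higher number from compound 1 to compound 2 (0.17 log units; within the scatter). Because a 1.5-fold higher number from compound 1 to compound 2 (0.17 log units; within the scatter) stayed within the scatter, only a modest shift toward weaker inhibition is expected for compound 4. Compound 4 is therefore estimated at 24000 nM, with a likely range from 12000 nM to 50000 nM.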

Compound 4, concentration for 50% growth inhibition: 17000 nM
Beside the measured number, compound 4's estimate is 1.4-fold (0.15 log units) above it; the range from low to high includes it.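

On the core shared by compound 3 and compound 4, putting bromo in place of methyl gives a 1.1-fold higher number from compound 3 to compound 4 (0.03 log units; within the scatter) in this assay, so this step, like the earlier one, cannot be told apart from the noise of repeat measurements. Set side by side, the two steps do not differ, which means the swap behaves alike on both cores: the same change on two cores in this assay, a 1.5-fold higher number (0.17 log units; within the scatter) from compound 1 to compound 2 and a 1.1-fold higher number (0.03 log units; within the scatter) from compound 3 to compound 4, 1.4-fold (0.14 log units) apart, within the scatter of two such steps

This shows that, for these two pairs, methyl and bromo on this aromatic carbon can be exchanged on either core with no measurable effect on growth inhibition, but it does not show that a change with a clear effect would carry over in the same way, since a step within the scatter on both cores is a weak test of transfer, and two cores cannot speak for the whole series.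

The compounds shown leave open whether a different kind of group on this same aromatic carbon, such as an amine or a carboxylic acid, would produce a step beyond the scatter on either core. They also leave open whether such a step, if it appeared on one core, would be matched on the other.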